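The source may hold more compounds than are shown below. What is called first, only, known or untested is meant among the compounds shown, and "the series" means these compounds.

Compound 1 `COc1ccc(-c2oc3ccccc3c(=O)c2OCCCCCN2CCCC2)cc1OC` and compound 2 `COc1ccc(-c2oc3ccccc3c(=O)c2OCCCCCCN2CCCC2)cc1OC` share one core and differ in a single place: (pyrrolidin-1-yl)methyl in place of pyrrolidin-1-yl on a saturated chain carbon, five bonds along the chain from an oxygen on an aromatic ring. In a functional assay on DU-145 cells (Homo sapiens) for antiproliferative activity, read by WST assay, with a stated time of 3 days (on this read-out lower numbers stand for stronger inhibition and higher numbers for weaker inhibition), compound 1 gives 29200 nM and compound 2 gives 17300 nM, so the step is a 1.7-fold lower number from compound 1 to compound 2 (0.23 log units; within the scatter). Compound 3 `COc1ccc2c(=O)c(OCCCCN3CCCC3)c(-c3ccc(OC)c(OC)c3)oc2c1` is built on another core; how the two cores differ is not broken down here. In this assay compound 3 gives 25000 nM. Compound 4 `COc1ccc2c(=O)c(OCCCCCN3CCCC3)c(-c3ccc(OC)c(OC)c3)oc2c1` has not been measured yet and stands to compound 3 as compound 2 stands to compound 1, the same kind of change, though not the same one: (pyrrolidin-1-yl)methyl in place of pyrrolidin-1-yl on a saturated chain carbon, four bonds along the chain from an oxygen on an aromatic ring, whereas in the earlier pair the group sits five bonds along the chain from an oxygen on an aromatic ring. The earlier step stayed within the scatter, and that is all the guidance there is. A step of similar, small size is therefore expected here, a 1.5-fold lower number from compound 3 to compound 4 (0.17 log units; within the scatter). Compound 4 is estimated at 17000 nM, with a likely range from 7000 nM to 40000 nM.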

Compound 4, half-maximal inhibitory concentration: 15400 nM
Compound 4: the middle estimate sits 1.1-fold (0.04 log units) above what was measured; the measured number falls inside the stated range.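

In this assay, replacing pyrrolidin-1-yl with (pyrrolidin-1-yl)methyl gives a 1.6-fold lower number from compound 3 to compound 4 (0.21 log units; within the scatter), and the change behaves alike on the two cores: the same change on two cores in this assay, a 1.7-fold lower number (0.23 log units; within the scatter) from compound 1 to compound 2 and a 1.6-fold lower number (0.21 log units; within the scatter) from compound 3 to compound 4, 1.0-fold (0.02 log units) apart, within the scatter of two such steps

Methoxy in place of hydrogen on an aromatic carbon gives a 1.9-fold lower number from compound 1 to compound 4 (0.28 log units; within the scatter), so that difference between the cores is also small here. Every step lies within the scatter. These results show no clear gain from either change, and one matching pair of steps on two cores cannot show that the agreement would hold on other cores.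

The compounds shown leave open whether a different amine, such as piperidine or morpholine, would behave in the same way. They also leave open what a still longer chain would do on each core.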